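Cytotoxicity notes: swapping the benzyloxy arm for 4-chlorophenyl

A few compounds are considered here, and "the series" means these few. Any claim that something is new, unique, unknown or untested is made for them only; others in the source may bear on it.

Of the compounds shown here, three have been measured in a functional assay on HEL cells (Homo sapiens); on this read-out higher numbers stand for lower toxicity in this test and lower numbers for higher toxicity in this test. Compound 1 `O=C1c2ccccc2N(COCc2ccccc2)S(=O)(=O)N1Cc1ccccc1` gives 122000 nM in this assay. Compound 2 `O=S1(=O)N=C(OCc2ccccc2)c2ccccc2N1Cc1ccc(Cl)c(Cl)c1` gives 200000 nM, and compound 3 `O=S1(=O)N=C(OCc2ccccc2)c2ccccc2N1Cc1ccccc1` gives 200000 nM. Compound 1 holds the lowest of the three numbers, but both gaps to the other two fall within the scatter, so no order among them can be claimed.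

Compound 4 `O=C1c2ccccc2N(Cc2ccc(Cl)cc2)S(=O)(=O)N1Cc1ccccc1` is not yet measured. It differs from compound 1 as follows: 4-chlorophenyl in place of benzyloxy on a saturated chain carbon bound to a sulfonamide nitrogen in a ring. Among the measured compounds shown here, the only measured step at this place is no change at the digits printed from compound 2 to compound 3 (within the scatter), in which the aryl group on the saturated chain carbon bound to the sulfonamide nitrogen was exchanged with no effect on the number. For the measured compounds named here, that step is on a core differing from that of compound 1, so the bearing is indirect, but it is the only guide. For compound 4, the step of a 1.2-fold higher number from compound 1 to compound 4 (0.09 log units; within the scatter) is therefore expected to lie within the scatter. The estimate for compound 4 in this assay is 150000 nM, with a range from 70000 nM to 300000 nM.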

Compound 4, minimum cytotoxic concentration: > 5000 nM
Compound 4: no number, only a limit (the forecaster's own chance of this, stated with the estimate: 30%); the middle value does not contradict the limit.
By their numbers in this assay, from the lowest: compounds 1, 2 and 3 (each within the scatter of the next).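

In this assay, among the compounds shown here, compound 4 gives > 5000 nM, which is a limit and not a number, so no step from compound 1 to compound 4 can be read. The compounds shown leave open whether 4-chlorophenyl in place of benzyloxy changes the read-out on this core.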